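Aminopyrazine series: amine linker and five-membered ring swap

This account rests on a few compounds, and the source may have more. Where it says the series, first, only, none or still open, it means among the compounds named here.

Measured so far:
compound 1, `Cn1cc(-c2cnc(N)c(Oc3ccc(C(=O)Nc4cccc(Cl)c4)cc3)n2)cn1`: 4460 nM
compound 2, `Cc1noc(C)c1-c1cnc(N)c(NCc2ccc(C(=O)Nc3ccc(Cl)cc3)cc2)n1`: > 100000 nM

In a functional assay on HeLa cells (Homo sapiens) for inhibition, read by MTT assay, with a stated time of 72 h (a higher number here means a weaker inhibitor, a lower number a stronger inhibitor), compound 1 gives 4460 nM. Compound 2 is a different case: in this assay compound 2 gives only a limit, > 100000 nM, so no number stands for it. Of the two values measured, one sits at this limit (the limit of > 100000 nM in this assay, at which 1 of the 2 values shown sits). Compound 2 thus stands at the weak end of what is shown, with no measured distance to compound 1 that could be stated as a step, since the two differ in more than one place.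

Compound 3, `Cn1cc(-c2cnc(N)c(NCc3ccc(C(=O)Nc4ccc(Cl)cc4)cc3)n2)cn1`, is not yet measured. It carries 1-methyl-1H-pyrazol-4-yl in place of 3,5-dimethyl-1,2-oxazol-4-yl on an aromatic carbon. Within the data shown here, the entering group is the one that compound 1 also carries, though compound 1 differs from compound 3 elsewhere in the structure, so the value of compound 1 is only a loose guide. The step from compound 2 to compound 3 is expected to go toward stronger inhibition, an at least 3.3-fold lower number from compound 2 to compound 3 (0.52 log units; beyond the scatter), beyond the scatter but with little certainty about its size. In this assay compound 3 is estimated at 30000 nM, within 6000 nM to 100000 nM, and a limit-only result remains possible.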

Compound 3, half-maximal inhibitory concentration: 42100 nM
Compound 3: the middle estimate sits 1.4-fold (0.15 log units) below what was measured, within the range that was stated.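

Among these compounds, with the rest of the structure unchanged, 1-methyl-1H-pyrazol-4-yl in place of 3,5-dimethyl-1,2-oxazol-4-yl on an aromatic carbon gives the first readable step: an at least 2.3-fold lower number from compound 2 to compound 3 (0.37 log units; beyond the scatter). Among the compounds shown here, the earlier compounds offered no single-place comparison, so this is the first indication that the five-membered ring at this position, para to an amino group, affects the result in this assay, even though the entering and leaving groups have similar counts and both carry one five-membered aromatic ring with 2 hetero atoms. The step gives only a lower bound on the size of the change because compound 2 sits at a limit, not at a measured number: the limit of > 100000 nM in this assay, at which 1 of the 3 values shown sits.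

Compound 1 differs from compound 3 in more than one place, so the effects of its linker and of the placement of its chlorine remain unseparated. Also open, on these data alone, is how a group outside this pair of five-membered rings, such as a phenyl ring or a morpholine, would behave on the same aromatic carbon in this assay.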